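Nitro to methylselenyl on the aryl ketone ring

This account rests on a few compounds, and the source may have more. Where it says the series, first, only, none or still open, it means among the compounds named here.

Compound 1 `COc1ccc2c(/C=C/C(=O)c3cc(N)c(OC)c(OC)c3)cn(C)c2c1` gives 455 nM in a functional assay on HCT-8 cells (Homo sapiens) for antiproliferative activity, read by MTT assay, with a stated time of 48 h; a lower number here means a stronger inhibitor, a higher number a weaker inhibitor. Compound 2 `COc1ccc2c(/C=C/C(=O)c3cc(OC)c(OC)c([N+](=O)[O-])c3)cn(C)c2c1`, carrying nitro in place of amino on an aromatic carbon, gives 753 nM in this assay; the step is a 1.7-fold higher number from compound 1 to compound 2 (0.22 log units; within the scatter). Compound 3 `COc1ccc2c(/C=C/C(=O)c3cc(OC)c(OC)c([N+](=O)[O-])c3)c[nH]c2c1`, with hydrogen in place of methyl on an aromatic nitrogen, gives 982 nM in this assay, the step being a 1.3-fold higher number from compound 2 to compound 3 (0.12 log units; within the scatter). Of the three numbers, that of compound 3 is the highest; compound 2 sits within the scatter of it, compound 1 beyond it.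

Compound 4 `COc1ccc2c(/C=C/C(=O)c3cc(OC)c(OC)c([Se]C)c3)c[nH]c2c1` differs from compound 3 by a group of 2 heavy atoms (1 carbon, 1 selenium; no ring) in place of a group of 3 heavy atoms (1 nitrogen, 2 oxygen; no ring), on an aromatic carbon, the new group sitting on an aromatic carbon of a six-membered aromatic ring of carbon only, ortho to a methoxy group. Only the change from compound 1 to compound 2 concerns the same carbon, and that step, a 1.7-fold higher number from compound 1 to compound 2 (0.22 log units; within the scatter), stayed within the scatter; the hydrogen-for-methyl step on the aromatic nitrogen did likewise. Among the measured compounds shown here, no measured step involves selenium. The expectation is therefore a step of a 1.1-fold lower number from compound 3 to compound 4 (0.04 log units; within the scatter), not beyond the scatter in either direction. Compound 4 is estimated at 900 nM in this assay, within 350 nM to 2300 nM.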

Compound 4, half-maximal inhibitory concentration: 78 nM
Estimate against measurement, compound 4: 12-fold (1.06 log units) above; the measured number lies below the stated range.
By their numbers in this assay, from the lowest: compound 4; then compounds 1, 2 and 3 (each within the scatter of the next, the first and the last beyond it).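

At this aromatic carbon, ortho to a methoxy group, the nitro-for-amino exchange (a 1.7-fold higher number from compound 1 to compound 2 (0.22 log units; within the scatter)) stayed within the scatter, so the position could have seemed indifferent to its substituent. Methylselenyl in place of nitro (a 13-fold lower number from compound 3 to compound 4 (1.10 log units; beyond the scatter)) shows otherwise: in this assay the group on this carbon can produce a large step, here on the core bearing hydrogen on the aromatic nitrogen. Nothing available explains the size of this step.

The compounds shown do not separate a contribution of selenium from that of losing nitro, and methylthio, methoxy or ethylselenyl on the same carbon would address this. Also open, as far as these compounds go, is whether methylselenyl gives a similar step on the core carrying methyl on the aromatic nitrogen.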